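From Oxolan-3-yl to 2-Methoxyphenyl: Expected Cytotoxicity

A few compounds are considered here, and "the series" means these few. Any claim that something is new, unique, unknown or untested is made for them only; others in the source may bear on it.

compound 1, `c1ccc(-c2nc3ccccn3c2Nc2ccc3c(c2)OCCO3)nc1`, 25600 nM
compound 2, `c1ccc(-c2nc3ccccn3c2NC2CCOC2)nc1`, > 50000 nM

Two compounds have been examined in an ADME assay on THP-1 cells (Homo sapiens) for cytotoxicity; on this read-out higher numbers stand for lower toxicity in this test and lower numbers for higher toxicity in this test. Compound 1 `c1ccc(-c2nc3ccccn3c2Nc2ccc3c(c2)OCCO3)nc1` gives 25600 nM. For compound 2 `c1ccc(-c2nc3ccccn3c2NC2CCOC2)nc1` the result is only a limit of the assay, > 50000 nM. Compound 2 therefore stands at the limit of > 50000 nM in this assay, at which 1 of the 2 values shown sits, and no number is known for it. Compound 3 `COc1ccccc1Nc1c(-c2ccccn2)nc2ccccn12` has not yet been measured. It differs from compound 2 in one place: 2-methoxyphenyl in place of oxolan-3-yl on a nitrogen on an aromatic ring. For the measured compounds named here, no step between measured compounds is available, so the expectation for compound 3 rests on the two values alone. Compound 1, which also carries an aromatic group on the nitrogen on an aromatic ring, sits at a measured number rather than at the limit, while compound 2 with oxolan-3-yl sits at the limit. Compound 3 is expected to move toward a measurable value, with the step estimated as an at least 1.6-fold lower number from compound 2 to compound 3 (0.22 log units; that floor lies within the scatter). The estimate for compound 3 in this assay is 30000 nM, with a range from 12000 nM to 60000 nM.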

Compound 3, half-maximal cytotoxic concentration: > 50000 nM
Compound 3 ended at the assay's limit (the forecaster's own chance of this, stated with the estimate: 35%); at least 1.6-fold (0.22 log units) between middle value and limit.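

For the compounds shown here, compound 2 and compound 3 both stand at a limit of the range in this assay, so no step between them can be read: the limit of > 50000 nM in this assay, at which 2 of the 3 values shown sit. The compounds shown leave open whether 2-methoxyphenyl in place of oxolan-3-yl changes the read-out at all, and in which direction.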